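Lengthening the Side Chain on Compound 3

The source may hold more compounds than are shown below. What is called first, only, known or untested is meant among the compounds shown, and "the series" means these compounds.

Among the three compounds measured so far, compound 3 `CCC(c1ccccc1)n1ccc2cc(/C(C)=C/C(=O)Nc3ccccc3OCCCC(=O)O)ccc21` gives 19 nM in an assay on Prostate gland for inhibition of steroid 5-alpha-reductase (Rattus norvegicus) (on this read-out lower numbers stand for stronger inhibition and higher numbers for weaker inhibition), the lowest number of the set. Compound 1 `CCCCCCCn1ccc2cc(/C(C)=C/C(=O)Nc3ccccc3OCCCC(=O)O)ccc21` gives 120 nM and compound 2 `C/C(=C\C(=O)Nc1ccccc1OCCCC(=O)O)c1ccc2c(ccn2Cc2ccccc2C)c1` gives 69 nM. Compound 4 `CCCCCC(c1ccccc1)n1ccc2cc(/C(C)=C/C(=O)Nc3ccccc3OCCCC(=O)O)ccc21` differs from compound 3 by propyl in place of hydrogen on a saturated chain carbon, three bonds along the chain from an aromatic carbon and an aromatic nitrogen. Among the measured compounds shown here, no measured step changes only this part. The two steps that bear on it both end at compound 3: a 6.3-fold lower number from compound 1 to compound 3 (0.80 log units; beyond the scatter) and a 3.6-fold lower number from compound 2 to compound 3 (0.56 log units; beyond the scatter). Each replaced the whole group on the aromatic nitrogen and moved this assay modestly, but neither shows what a longer chain alone does. Compound 4 is therefore expected to move only a little, a 1.3-fold higher number from compound 3 to compound 4 (0.12 log units; within the scatter), which may lie within the scatter. The estimate for compound 4 is 25 nM, in a range from 8 nM to 80 nM.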

Compound 4, half-maximal inhibitory concentration: 25 nM
For compound 4 middle estimate and measured number coincide at the digits printed; low and high end bracket the measured number.
By their numbers in this assay, from the lowest: compounds 3 and 4 (each within the scatter of the next); then compounds 2 and 1 (each within the scatter of the next).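

In this assay, a 1.3-fold higher number from compound 3 to compound 4 (0.12 log units; within the scatter) lies within the scatter, so propyl in place of hydrogen on this saturated chain carbon has no readable effect, and 1-phenylhexyl serves as well as 1-phenylpropyl. The longer chain also keeps the advantage over the other groups on the aromatic nitrogen: a 2.8-fold lower number from compound 2 to compound 4 (0.44 log units; beyond the scatter) and a 4.8-fold lower number from compound 1 to compound 4 (0.68 log units; beyond the scatter) both lie beyond the scatter. On these data alone, how far this chain can grow remains open, as does whether an amine or a carboxylic acid at its end would be accepted. Nothing measured here offers a reason for these numbers.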